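Bromo for fluoro on a rhodanine-type benzylidene: cytotoxicity

The source may report more compounds than this note shows. Statements on the series, on what has been measured and on what is new or still open speak of the compounds shown alone.

Measured so far:
compound 1 `O=C1NC(=S)/C(=C/c2ccccc2Br)S1` gives 21.2%
compound 2 `O=C1NC(=S)/C(=C/c2cccc(F)c2)S1` gives 20.9%
compound 3 `O=C1NC(=S)/C(=C/c2ccccc2F)S1` gives 11.2%

All three were tested in a functional assay on HEp-2 cells (Homo sapiens) for cytotoxicity, read by MTT assay, with a stated time of 72 h, tested at 10 ug/mL; a higher number here means more inhibition of growth at the concentration tested, a lower number less inhibition of growth. Compound 2 and compound 3 share the same atoms joined differently; the difference between the two cores is not broken down here. Compound 1 differs from compound 3 by bromo in place of fluoro on an aromatic carbon, a change sitting ortho to a group of 8 heavy atoms, and this step gave a number 10 percentage points higher from compound 3 to compound 1 (within the scatter).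

Compound 4 `O=C1NC(=S)/C(=C/c2cccc(Br)c2)S1` is not yet measured. It differs from compound 2 by bromo in place of fluoro on an aromatic carbon, the same kind of change, here sitting meta to a group of 8 heavy atoms. Because a number 10 percentage points higher from compound 3 to compound 1 (within the scatter) stayed within the scatter, a similarly small step is expected from compound 2 to compound 4 in this assay, about a number 4.1 percentage points higher from compound 2 to compound 4 (within the scatter). Compound 4 is therefore estimated at 25%, roughly between 10% and 40%.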

Compound 4, percent growth inhibition at one concentration: 23.6%
For compound 4 the middle estimate is 1.4 percentage points above the measured one; the range from low to high includes it.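

In this assay, bromo in place of fluoro gave a number 2.7 percentage points higher from compound 2 to compound 4 (within the scatter) and, set beside the earlier step, the result on the two cores shows no real difference: the same change on two cores in this assay, a number 10 percentage points higher (within the scatter) from compound 3 to compound 1 and a number 2.7 percentage points higher (within the scatter) from compound 2 to compound 4, 7.3 percentage points apart, within the scatter of two such steps. Within these two pairs, then, the change carries from one core to the other without a detectable shift. This does not show that bromo truly raises growth inhibition, as both steps lie within the scatter, and two pairs say nothing about cores outside them.

Only fluoro and bromo appear on the aromatic ring here, leaving open how an amine or a carboxylic acid at the same place would behave. Also open, going by these compounds, is whether any single change on these cores can move the number beyond the scatter.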